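Amide ring swap: compound 3 to compound 4

The source may hold more compounds than are shown below. What is called first, only, known or untested is meant among the compounds shown, and "the series" means these compounds.

Measured in a functional assay on HBC4 cells (Homo sapiens) for inhibition, read by colorimetric assay and sulforhodamine B assay, with a stated time of 48 h; a lower number here means a stronger inhibitor of growth, a higher number a weaker inhibitor of growth:
compound 1 `CCCCCCCCCCCC[C@@H](O)[C@H]1CC[C@H]([C@H](O)CCCCCCCCCCNC(=O)c2cccs2)O1`: 3390 nM
compound 2 `CCCCCCCCCCCC[C@@H](O)[C@H]1CC[C@H]([C@H](O)CCCCCCCCCCNC(=O)c2ccco2)O1`: 100000 nM
compound 3 `CCCCCCCCCCCC[C@@H](O)[C@H]1CC[C@H]([C@H](O)CCCCCCCCCCNC(=O)c2ccsc2)O1`: 100000 nM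

Compound 3 at 100000 nM stands level with compound 2, together the highest of the three numbers. Compound 4 `CCCCCCCCCCCC[C@@H](O)[C@H]1CC[C@H]([C@H](O)CCCCCCCCCCNC(=O)c2ccnn2C)O1` has 1-methyl-1H-pyrazol-5-yl in place of thiophen-3-yl on a carbonyl carbon. Two large steps lead away from compound 1: a 29-fold higher number from compound 1 to compound 2 (1.47 log units; beyond the scatter) and a 29-fold higher number from compound 1 to compound 3 (1.47 log units; beyond the scatter). The third, no change at the digits printed from compound 2 to compound 3 (within the scatter), lies within the scatter. Among the compounds with values here, no measured compound carries the entering group, so only a weak guide exists, and no step beyond the scatter is expected in this assay. The estimated step is a 1.7-fold lower number from compound 3 to compound 4 (0.22 log units; within the scatter). Compound 4 is expected at 60000 nM, within an estimated range of 5000 nM to 100000 nM.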

Compound 4, concentration for 50% growth inhibition: 100000 nM
The estimate for compound 4 lay 1.7-fold (0.22 log units) below the measured number; low and high end bracket the measured number.
By their numbers in this assay, from the lowest: compound 1; then compounds 2, 3 and 4 (each within the scatter of the next).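

In this assay, the 1-methyl-1H-pyrazol-5-yl amide, with two hetero atoms in its ring, sits with the single-hetero-atom rings of the thiophen-3-yl and furan-2-yl amides (no change at the digits printed from compound 3 to compound 4 (within the scatter); no change at the digits printed from compound 2 to compound 4 (within the scatter)). The separate step (a 29-fold higher number from compound 1 to compound 4 (1.47 log units; beyond the scatter)) extends the gap seen earlier, so that among these four amides only the thiophen-2-yl of compound 1 stands apart beyond the scatter. No available evidence accounts for this separation. Open, going by these compounds, is whether a phenyl or a 5-methylthiophen-2-yl on the same carbonyl carbon would fall with compound 1 or with compounds 2, 3 and 4.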